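This account rests on a few compounds, and the source may have more. Where it says the series, first, only, none or still open, it means among the compounds named here.

Measured in a functional assay on SGC-7901 cells (Homo sapiens) for antiproliferative activity, read by MTT assay, with a stated time of 24 h; a lower number here means a stronger inhibitor, a higher number a weaker inhibitor:
Compound 1 `Cc1ccccc1NNC(=O)c1ccc(NS(=O)(=O)c2cnc(O)nc2O)cc1`: > 20000 nM (a limit)
Compound 2 `O=C(NNc1ccccc1Cl)c1ccc(NS(=O)(=O)c2cnc(O)nc2O)cc1`: 3630 nM
Compound 3 `Cc1ccccc1NNC(=O)c1ccccc1NS(=O)(=O)c1cnc(O)nc1O`: > 20000 nM (a limit)
Compound 4 `O=C(NNc1ccccc1F)c1ccccc1NS(=O)(=O)c1cnc(O)nc1O`: not yet measured

In this assay compound 3 gives > 20000 nM, which is a limit and not a number. It sits at the limit of > 20000 nM in this assay, at which 2 of the 3 values shown sit. Compound 4 differs from it by fluoro in place of methyl on an aromatic carbon, with fluoro in place of methyl on an aromatic carbon, ortho to a large group. The nearest measured change is chloro in place of methyl, an at least 5.5-fold lower number from compound 1 to compound 2 (0.74 log units; beyond the scatter). That step has a different entering group and a different parent, so it is only a loose guide. A smaller move towards a lower number is therefore expected, and the estimate is an at least 1.4-fold lower number from compound 3 to compound 4 (0.15 log units; that floor lies within the scatter). Compound 4 is estimated at 14000 nM, with an expected range of 4000 nM to 30000 nM.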

Compound 4, half-maximal inhibitory concentration: > 20000 nM
Compound 4: only a limit was reported; the forecaster's own chance of this, stated with the estimate: 55%; at least 1.4-fold (0.15 log units) between middle value and limit.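

Among these compounds, compound 3 and compound 4 both gave only a limit, and no step between them can be read. The compounds shown leave open whether fluoro in place of methyl changes antiproliferative activity here at all.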